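Swapping ethyl for cyclohexyl on a fluorophenyl series

The source may report more compounds than this note shows. Statements on the series, on what has been measured and on what is new or still open speak of the compounds shown alone.

compound 1 `CCc1nc(-c2ccccc2F)c(C(=O)N2CCN(c3cccc(Cl)c3)CC2)o1`: 139 nM
compound 2 `CCc1nc(-c2cccc(F)c2)c(C(=O)N2CCN(c3cccc(Cl)c3)CC2)o1`: 317 nM

Both values come from a functional assay on HL-60 cells (Homo sapiens) for inhibition, read by MTT assay, with a stated time of 72 h; on this read-out higher numbers stand for weaker inhibition and lower numbers for stronger inhibition. Of the two numbers, compound 1 holds the lower, and compound 2 is its nearest neighbour. The next candidate is compound 3 `O=C(c1oc(C2CCCCC2)nc1-c1ccccc1F)N1CCN(c2cccc(Cl)c2)CC1`, which keeps the 2-fluorophenyl group of compound 1 and changes another part of the molecule: cyclohexyl in place of ethyl on an aromatic carbon. In words, cyclohexyl stands in place of ethyl on an aromatic carbon.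

Within the data shown here, only one measured step is available, a 2.3-fold higher number from compound 1 to compound 2 (0.36 log units; beyond the scatter). It is a modest step, and it concerns the fluorophenyl group, so it bears on the new change only indirectly. Among the measured compounds shown here, no measured compound varies the ethyl position, so the data fix neither the size nor the direction of this step. For the measured compounds named here, it shows only that a single small change here can move the number beyond the scatter. A moderate step towards a higher number is expected, since compound 1 already stands lowest at 139 nM, but the uncertainty is wide. The expected change is a 2.0-fold higher number from compound 1 to compound 3 (0.30 log units; within the scatter). For compound 3 the estimated value is 280 nM, with an expected range from 60 nM to 1300 nM.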

Compound 3, half-maximal inhibitory concentration: "not active" (no number reported)
No number was reported for compound 3, so the estimate cannot be set against anything.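

Among these compounds, compound 3 was reported as "not active" with no number, so no step from compound 1 to compound 3 can be read. The compounds shown leave open how far cyclohexyl in place of ethyl moves the number away from the 139 nM of compound 1. Nothing measured here accounts for this result.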